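The source may hold more compounds than are shown below. What is called first, only, known or untested is meant among the compounds shown, and "the series" means these compounds.

Measured so far:
compound 1 `C=CC1=C(C(=O)NCc2ccccc2F)C(c2ccc(F)cc2)OC1` — > 100000 nM
compound 2 `C=CC1=C(C(=O)NCC(C)C)C(c2ccc(F)cc2)OC1` — > 100000 nM
compound 3 `C=CC1=C(C(=O)NC(C)(C)C)C(c2ccc(Cl)c(Cl)c2)OC1` — > 100000 nM

In a functional assay on A549 cells (Homo sapiens) for cytotoxicity, read by MTT assay, with a stated time of 24 h (a lower number here means a stronger inhibitor, a higher number a weaker inhibitor), compound 2 gives only a limit, > 100000 nM, and not a number. The same holds for compound 1 and compound 3: every value in the series sits at the limit of > 100000 nM in this assay, at which 3 of the 3 values shown sit. Compound 2 therefore stands nowhere in particular; it is merely among the three limits. Among the compounds with values here, the one step within the measured set, a step that the two limits leave unreadable from compound 1 to compound 2, is unreadable for that reason.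

Compound 4 `C=CC1=C(C(=O)Nc2cccc(C)c2)C(c2ccc(F)cc2)OC1` differs from compound 2 by 3-methylphenyl in place of isobutyl on an amide-type nitrogen. Within the data shown here, no measured step bears on an aromatic group on the amide nitrogen; the only neighbouring change is the unreadable one. The step from compound 2 to compound 4 is thus expected to be a step that the limit leaves unreadable from compound 2 to compound 4, most likely returning a limit again in this assay. Compound 4 is estimated at 150000 nM, range 40000 nM to 600000 nM.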

Compound 4, half-maximal inhibitory concentration: > 100000 nM
Compound 4 ended at the assay's limit; the forecaster's own chance of this, stated with the estimate: 80%; the middle value lies beyond the limit too.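

In this assay compound 4 gives > 100000 nM, a limit and not a number, so its steps from compound 1 and compound 2 cannot be read. Left open is whether any group on the amide nitrogen gives a measurable number in this assay.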